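The source may hold more compounds than are shown below. What is called first, only, known or untested is meant among the compounds shown, and "the series" means these compounds.

Measured compounds:
- compound 1 `CC(C)Cc1cc(-c2cccc(Cn3ccnc3)c2)c(S(=O)(=O)NC(=O)OC(C)C)s1`: 160 nM
- compound 2 `CC(C)Cc1cc(-c2cccc(Cn3ccnc3)c2)c(S(=O)(=O)NC(=O)OC2CCCC2)s1`: 180 nM

Among the measured compounds shown here, in an assay on HEK293 cells for displacement of a labelled ligand from Type-2 angiotensin II receptor (Homo sapiens), read by scintillation counting, with a stated time of 240 min (a higher number here means a weaker inhibitor, a lower number a stronger inhibitor), compound 1 gives 160 nM, the lowest of the two numbers so far, with compound 2 nearest at 180 nM; the only measured step, a 1.1-fold higher number from compound 1 to compound 2 (0.05 log units; within the scatter), is within the scatter, so the two compounds are not separable on these data.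

Compound 3 `CCCCCC(=O)NS(=O)(=O)c1sc(CC(C)C)cc1-c1cccc(Cn2ccnc2)c1` is the next member. It differs from compound 1 by pentyl in place of isopropoxy on a carbonyl carbon. Read one bond further out, this is isopropoxycarbonyl to pentylcarbonyl, or (isopropoxycarbonyl)amino to (pentylcarbonyl)amino.

For the measured compounds named here, only one measured step exists, and it altered the group on the oxygen while leaving the carbonyl carbon untouched; it was a 1.1-fold higher number from compound 1 to compound 2 (0.05 log units; within the scatter), within the scatter. Going by the values given here, no measured step exchanges the oxygen-linked group for a chain on the carbonyl carbon itself, so the data give no direct precedent for this change. The expectation is therefore a modest step at most, a 1.6-fold higher number from compound 1 to compound 3 (0.19 log units; within the scatter), with the direction uncertain and the range widened accordingly.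

Compound 3 is estimated at 250 nM in this assay, with a range from 80 nM to 800 nM.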

Compound 3, inhibition constant: 280 nM
The estimate for compound 3 lay 1.1-fold (0.05 log units) below the measured number; low and high end bracket the measured number.
By their numbers in this assay, from the lowest: compounds 1, 2 and 3 (each within the scatter of the next).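

In this assay, exchanging the oxygen-linked group for pentyl on the carbonyl carbon gives a 1.8-fold higher number from compound 1 to compound 3 (0.24 log units; within the scatter) and a 1.6-fold higher number from compound 2 to compound 3 (0.19 log units; within the scatter), so neither step separates compound 3 from its neighbours. Among the compounds shown here, the single earlier step changed only the group on the oxygen, whereas these steps also remove that oxygen, and the numbers of compound 1, compound 2 and compound 3 still cannot be told apart at this position. No independent measurement bearing on this result is available.

With only isopropoxy, cyclopentyloxy and pentyl compared, and with no step beyond the scatter, these compounds set no limit on what this carbonyl carbon accepts. Going by these compounds, it remains open whether a benzyl group, an amine or a much longer chain at this place would give a number clearly separate from these, and whether the same result would hold with changes elsewhere on the shared core.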